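Swapping a cyano for an ethynyloxy on a weak nucleoside analogue

The source may hold more compounds than are shown below. What is called first, only, known or untested is meant among the compounds shown, and "the series" means these compounds.

Of the compounds shown here, two have been tested in an ADME assay on L1210/0 cells (Mus musculus) for cytotoxicity, with a stated time of 48 h; a lower number here means a stronger inhibitor, a higher number a weaker inhibitor. Going by the values given here, compound 1 `COc1ccccc1C(=O)/C=C/c1cc(=O)[nH]c(=O)n1COCCO` gives 15200 nM and is therefore the only one of the pair with a measured number. Compound 2 `N#Cc1cn([C@H]2C[C@H](O)[C@@H](CO)O2)c(=O)[nH]c1=O` reaches only a limit, > 200000 nM, so it stands at the top edge of what this assay can report, as recorded in the limit of > 200000 nM in this assay, at which 1 of the 2 values shown sits. Compound 3 `C#COc1cn([C@H]2C[C@H](O)[C@@H](CO)O2)c(=O)[nH]c1=O` has not yet been measured. It keeps the core of compound 2 and differs in one place: ethynyloxy in place of cyano on an aromatic carbon. Among the compounds with values here, with no measured step for comparison, the expectation is no movement beyond the usual scatter, and the change from compound 2 to compound 3 is estimated as a number no higher from compound 2 to compound 3 (the limit leaves the size open). Compound 3 is thus expected to give about 200000 nM, within a range from 50000 nM to 600000 nM, most likely again only as a limit.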

Compound 3, half-maximal inhibitory concentration: > 200000 nM
Compound 3 ended at the assay's limit; the forecaster's own chance of this, stated with the estimate: 75%; the middle value sits exactly at the limit.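

Compound 2 and compound 3 both end at a limit of the assay rather than at a number, so swapping cyano for ethynyloxy gives no readable step: the limit of > 200000 nM in this assay, at which 2 of the 3 values shown sit.

The compounds shown leave open whether ethynyloxy and cyano differ at all in this assay.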